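This account rests on a few compounds, and the source may have more. Where it says the series, first, only, none or still open, it means among the compounds named here.

Compound 1 `O=C(CCSc1nc2cc(Cl)ccc2o1)N1CCC1` sits at the top of the three compounds measured in an ADME assay on microsomes from liver (Mus musculus) for metabolic stability, read by LC-MS, using NADPH, with a stated time of 45 min, tested at 0.5 uM (on this read-out higher numbers stand for fast clearance and lower numbers for slow clearance), where compound 1 gives 17.9 mL/min/g. The gap to the other two is well beyond the scatter: in this assay compound 2 `CS(=O)(=O)N1CCN(C(=O)CCSc2nc3cc(Cl)ccc3o2)CC1` gives 1.4 mL/min/g, and compound 3 `CN(C(=O)CCSc1nc2cc(F)ccc2o1)C1CCS(=O)(=O)CC1` gives 0.6 mL/min/g, so compound 1 stands clearly as the fastest-cleared of the set and compound 3 as the slowest.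

The account turns from compound 1 to compound 4 `CN(C)C(=O)CCSc1nc2cc(Cl)ccc2o1`, a compound not yet measured. The change is a small one (dimethylamino in place of azetidin-1-yl on a carbonyl carbon); the amide nitrogen keeps two carbon substituents, one ring is lost and no donor or acceptor is added or removed. For the measured compounds named here, no measured pair in the set isolates this kind of change, so the expectation rests on the size of the edit alone. Compound 4 is expected to stay close to compound 1, with the estimated step from compound 1 to compound 4 in this assay of a 1.2-fold lower number from compound 1 to compound 4 (0.08 log units; within the scatter) lying within the scatter. Compound 4 is therefore estimated at 15 mL/min/g, in a range from 6 mL/min/g to 35 mL/min/g.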

Compound 4, intrinsic clearance in a liver preparation (reported as CLH), per the amount of preparation that the assay uses: 41.8 mL/min/g
Compound 4: middle estimate off by 2.8-fold (0.45 log units), on the low side; measured number outside the range, above it.
By their numbers in this assay, from the lowest: compound 3; then compound 2; then compound 1; then compound 4.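

In this assay, the place on the carbonyl carbon proves sensitive to a small edit: dimethylamino in place of azetidin-1-yl gives a 2.3-fold higher number from compound 1 to compound 4 (0.37 log units; beyond the scatter) and so is a modest step, yet one beyond the scatter. For the compounds shown here, the earlier compounds held no pair differing in one place, so this is the first direct reading at this position, and it shows that losing the ring moves the number upward even though neither group carries a hydrogen-bond donor or acceptor. Nothing measured here accounts for the direction of this step.

The compounds shown leave open whether another group on this carbonyl carbon, such as pyrrolidin-1-yl or diethylamino, would lie nearer compound 1 or compound 4. They also leave open whether the same exchange would give a step of similar size on a different core.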